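A bromo swap at the assay limit

The source may hold more compounds than are shown below. What is called first, only, known or untested is meant among the compounds shown, and "the series" means these compounds.

In an ADME assay on HeLa cells (Homo sapiens) for cytotoxicity, read by resazurin assay, with a stated time of 2 days (on this read-out higher numbers stand for weaker inhibition and lower numbers for stronger inhibition), compound 1 `Cn1c([N+](=O)[O-])cnc1/C=C/c1ccccc1` gives > 100000 nM as a limit, not a number. Compound 2 `CC(=O)OC(c1ccc(C)cc1)C(OC(C)=O)c1ncc([N+](=O)[O-])n1C` gives > 100000 nM as a limit too, so it has no exact value. Compound 3 `CC(=O)OC(c1ccc(Br)cc1)C(OC(C)=O)c1ncc([N+](=O)[O-])n1C` carries bromo in place of methyl on an aromatic carbon and so turns 4-methylphenyl into 4-bromophenyl. Among the compounds with values here, no measured step shows what this swap does. Resting on the limit of > 100000 nM in this assay, at which 2 of the 2 values shown sit, alone, the expected a number no higher from compound 2 to compound 3 (the limit leaves the size open) in this assay is no larger than the usual scatter. For compound 3 the estimated value is 100000 nM with an expected range from 40000 nM to 150000 nM and a good chance of another limit.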

Compound 3, half-maximal inhibitory concentration: 97700 nM
Beside the measured number, compound 3's estimate is 1.0-fold (0.01 log units) above it; measured number inside the range.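

In this assay, turning 4-methylphenyl into 4-bromophenyl gives the first exact number among the compounds shown, with compound 3 at 97700 nM. The change amounts to an at least 1.0-fold lower number from compound 2 to compound 3 (0.01 log units; that floor lies within the scatter), so nothing here shows bromo moving the number beyond the scatter. The true size of the step stays unknown because compound 2 carries only a limit: the limit of > 100000 nM in this assay, at which 2 of the 3 values shown sit.

The compounds shown leave open what an amine, a carboxylic acid or a longer chain would do in place of bromo on that aromatic carbon.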